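A few compounds are considered here, and "the series" means these few. Any claim that something is new, unique, unknown or untested is made for them only; others in the source may bear on it.

Three analogues built on one shared core have been measured in a functional assay on NCI-H460 cells (Homo sapiens) for cytotoxicity, read by MTT assay, with a stated time of 72 h; a lower number here means a stronger inhibitor, a higher number a weaker inhibitor. Compound 1 `COc1ccc(/C=N/NC(=O)Nc2ccc(Oc3ccnc(-c4nncn4CCN(C)C)c3)c(F)c2)c(OC)c1` gives 1570 nM in this assay, compound 2 `CN(C)CCn1cnnc1-c1cc(Oc2ccc(NC(=O)N/N=C/c3ccc(Cl)cc3)cc2F)ccn1` gives 320 nM, and compound 3 `CN(C)CCn1cnnc1-c1cc(Oc2ccc(NC(=O)N/N=C/c3cccc(O)c3)cc2F)ccn1` gives 780 nM. Compound 3 stands second highest of the three: the step of a 2.0-fold lower number from compound 1 to compound 3 (0.30 log units; within the scatter) lies within the scatter, while a 2.4-fold higher number from compound 2 to compound 3 (0.39 log units; beyond the scatter) lies beyond it, as does a 4.9-fold lower number from compound 1 to compound 2 (0.69 log units; beyond the scatter). Compound 4 `Cc1cc(/C=N/NC(=O)Nc2ccc(Oc3ccnc(-c4nncn4CCN(C)C)c3)c(F)c2)cc(C)c1O` differs from compound 3 by 4-hydroxy-3,5-dimethylphenyl in place of 3-hydroxyphenyl on a carbon with a double bond to nitrogen. No measured step carries this exact change; the three steps at the same carbon range from within the scatter to modest, so among these compounds the group on that carbon moves the number only moderately. Compound 4 is therefore expected to give 600 nM in this assay, within 250 nM to 1500 nM. The step of a 1.3-fold lower number from compound 3 to compound 4 (0.11 log units; within the scatter) is expected to stay near the scatter.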

Compound 4, half-maximal inhibitory concentration: 2010 nM
The estimate for compound 4 lay 3.4-fold (0.53 log units) below the measured number, outside the stated range (above it).
By their numbers in this assay, from the lowest: compound 2; then compounds 3, 1 and 4 (each within the scatter of the next, the first and the last beyond it).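

In this assay, placing 4-hydroxy-3,5-dimethylphenyl on the carbon with a double bond to nitrogen gave a 2.6-fold higher number from compound 3 to compound 4 (0.41 log units; beyond the scatter), so two phenyl groups that each carry a hydroxy group can differ beyond the scatter here. It also gave a 6.3-fold higher number from compound 2 to compound 4 (0.80 log units; beyond the scatter), while a 1.3-fold higher number from compound 1 to compound 4 (0.11 log units; within the scatter) leaves this group indistinguishable from 2,4-dimethoxyphenyl. Nothing available explains these differences. The compounds shown do not separate the two methyl groups from the place of the hydroxy group in this change, and they leave open how an aminophenyl or carboxyphenyl group on that carbon would read.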